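Pyrazole for methylpyridine on a shared quinazolinone core

The source may hold more compounds than are shown below. What is called first, only, known or untested is meant among the compounds shown, and "the series" means these compounds.

Measured so far in an ADME assay on THP-1 cells (Homo sapiens) for cytotoxicity, read by MTT assay, with a stated time of 72 h; a lower number here means that less compound is needed, a higher number that more compound is needed for the effect:
- Compound 1 `Cc1cc(-c2ccc3[nH]c(=O)nc(-c4ccccc4)c3c2)ccn1` gives > 50000 nM, a limit of this assay.
- Compound 2 `Cc1ccncc1-c1ccc2[nH]c(=O)nc(-c3ccccc3)c2c1` gives > 50000 nM, a limit of this assay.
- Compound 3 `O=c1nc(-c2ccccc2)c2cc(-c3cccc(F)c3)ccc2[nH]1` gives > 50000 nM, a limit of this assay.

Compound 2 stands where every measured compound stands: at the limit of this assay, since (the limit of > 50000 nM in this assay, at which 3 of the 3 values shown sit). Compound 4 `O=c1nc(-c2ccccc2)c2cc(-c3cn[nH]c3)ccc2[nH]1` differs from compound 2 by a single exchange (1H-pyrazol-4-yl in place of 4-methylpyridin-3-yl on an aromatic carbon).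

For the measured compounds named here, the steps that bear on this change are a step that the two limits leave unreadable from compound 1 to compound 2, a step that the two limits leave unreadable from compound 2 to compound 3 and a step that the two limits leave unreadable from compound 1 to compound 3. Each swaps one aromatic group at the same place on the shared core, and each is unreadable in size because both of its ends sit at the limit. They show that swapping that group among a 2-methylpyridin-4-yl, a 4-methylpyridin-3-yl and a 3-fluorophenyl has not moved any compound to a readable value. Going by the values given here, no step here gives a direction, so no step beyond the scatter is expected for the exchange to 1H-pyrazol-4-yl, and the most likely outcome is again a limit. The step from compound 2 to compound 4 is therefore expected to be a number no higher from compound 2 to compound 4 (the limit leaves the size open). Compound 4 is expected to give 50000 nM, in a range from 20000 nM to 120000 nM.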

Compound 4, half-maximal effective concentration: > 50000 nM
Compound 4: only a limit was reported (the forecaster's own chance of this, stated with the estimate: 85%); the middle value lies on the limit itself.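

In this assay compound 4 gives > 50000 nM, which is a limit. Its steps from compound 1, compound 2 and compound 3 cannot be read, because all four compounds share one limit: the limit of > 50000 nM in this assay, at which 4 of the 4 values shown sit. The compounds shown leave open how far apart their true values lie and which exchange on the shared core, if any, would give a readable value.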